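Phenoxy swap at the aryl ether: compound 1 to compound 4

The source may hold more compounds than are shown below. What is called first, only, known or untested is meant among the compounds shown, and "the series" means these compounds.

Compound 1 `Cc1ccccc1Oc1cccc(COc2ccccc2CCC(=O)OCCCOP(=O)(O)OC[C@H](N)C(=O)O)c1` is the reference point of the series. In an assay on cells for agonist activity at probable G-protein coupled receptor 34 (Mus musculus), with a stated time of 1 h (on this read-out lower numbers stand for smaller maximal responses and higher numbers for larger maximal responses), compound 1 gives 20.3%. Compound 2 `N[C@@H](COP(=O)(O)OCCCOC(=O)CCc1ccccc1OCc1cccc(Oc2ccc(F)cc2)c1)C(=O)O` gives 18.7% and compound 3 `N[C@@H](COP(=O)(O)OCCCOC(=O)CCc1ccccc1OCc1cccc(Oc2ccc(I)cc2)c1)C(=O)O` gives 19.1%, so all three stand together within the scatter of one another, and compound 1 is not set apart from either of them.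

Compound 4 `CCc1ccc(Oc2cccc(COc3ccccc3CCC(=O)OCCCOP(=O)(O)OC[C@H](N)C(=O)O)c2)cc1` has not yet been measured. It differs from compound 1 by 4-ethylphenyl in place of 2-methylphenyl on an oxygen on an aromatic ring. The measured steps that bear on this change all sit at the same place: a number 1.6 percentage points lower from compound 1 to compound 2 (within the scatter) and a number 1.2 percentage points lower from compound 1 to compound 3 (within the scatter) exchange the same aryl group, and a number 0.4 percentage points higher from compound 2 to compound 3 (within the scatter) exchanges the halogen on it. None of these steps moved the response beyond the scatter. No step beyond the scatter is therefore expected for compound 4; the change is expected to read a number 0.8 percentage points lower from compound 1 to compound 4 (within the scatter). Compound 4 is estimated at 19.5%, within 12% to 27%.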

Compound 4, largest response reached (Emax), in percent of the reference or control that the assay uses: 19.3%
Beside the measured number, compound 4's estimate is 0.2 percentage points above it, within the range that was stated.
By their numbers in this assay, from the lowest: compounds 2, 3, 4 and 1 (each within the scatter of the next).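

The earlier swaps at this place put only halogens on the phenyl ring, whereas 4-ethylphenyl puts an alkyl group there, and in this assay the exchange for 2-methylphenyl reads a number 1 percentage points lower from compound 1 to compound 4 (within the scatter) as the step. Ethyl also stands level with both halogens, since a number 0.2 percentage points higher from compound 3 to compound 4 (within the scatter) and a number 0.6 percentage points higher from compound 2 to compound 4 (within the scatter) leave the three substituted phenyl ethers unseparated, so on an oxygen on an aromatic ring the response has now held through fluoro, iodo and ethyl alike. Nothing measured on these compounds accounts for this flat response.

As far as these compounds go, whether any group on this ring can move the response remains open, for instance an amine, a carboxylic acid or a chain longer than ethyl. From the compounds shown here alone, it is equally open whether a 4-methylphenyl or an unsubstituted phenyl would read the same.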